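Trimming the isopropyl from compound 1

The source may report more compounds than this note shows. Statements on the series, on what has been measured and on what is new or still open speak of the compounds shown alone.

Compound 1 `CC(=O)OC[C@H]1O[C@@H](n2cc(-c3cn(Cc4ccc(C(C)C)cc4)nn3)c(=O)[nH]c2=O)C[C@@H]1OC(C)=O` and compound 2 `CC(=O)OC[C@H]1O[C@@H](n2cc(-c3cc(C)no3)c(=O)[nH]c2=O)C[C@@H]1OC(C)=O` share the same core and differ only in the group attached to it. In a functional assay on MDA-MB-231 cells (Homo sapiens) for cytotoxicity, read by sulforhodamine B assay, tested at 10 uM (a higher number here means more inhibition at the concentration tested (going by the name of the read-out), a lower number less inhibition), compound 1 gives 98.1%, the lower of the two numbers, while compound 2 gives 106%; the gap lies within the scatter, so neither stands apart from the other. For the measured compounds named here, no step between measured compounds is known. Compound 3 `CC(=O)OC[C@H]1O[C@@H](n2cc(-c3cn(Cc4ccccc4)nn3)c(=O)[nH]c2=O)C[C@@H]1OC(C)=O` has not yet been measured in this assay. It differs from compound 1 by one change: hydrogen in place of isopropyl on an aromatic carbon. Both measured compounds give high numbers in this assay that lie level with each other, leaving little room for a higher number. The expected step is small, a number 5.1 percentage points lower from compound 1 to compound 3 (within the scatter), most likely within the scatter and, if anything, downward. Compound 3 is therefore estimated to give 93%, with a likely range from 72% to 106%.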

Compound 3, a percentage reported as inhibition, at one concentration (the size of the read-out at that concentration, not a potency): 102%
The estimate for compound 3 lay 9 percentage points below the measured number, and the stated range covers the measured number.
By their numbers in this assay, from the lowest: compounds 1, 3 and 2 (each within the scatter of the next).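

In this assay, for the compounds shown here, the change from 4-isopropylbenzyl to benzyl gives a number 3.9 percentage points higher from compound 1 to compound 3 (within the scatter), the first step that can be read at this place on the six-membered aromatic ring. The isopropyl can therefore be replaced by hydrogen without a difference that stands clear of the scatter, so at this single concentration the read-out does not depend on that group. No measurement shown here accounts for this result.

The compounds shown leave open whether an amine, a carboxylic acid or a methoxy group at the same place would give a number that stands apart from those of compound 1 and compound 3. They also leave open whether these two compounds would separate at a lower concentration or in a read-out of potency.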